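A few compounds are considered here, and "the series" means these few. Any claim that something is new, unique, unknown or untested is made for them only; others in the source may bear on it.

Within the data shown here, compound 2 `COc1ccc2c(=O)c(/C=C/C(=O)NCc3ccccc3F)coc2c1` holds the only number among the two measured compounds: in a functional assay (QGY7701 cells, Homo sapiens) for inhibition, read by MTT assay, with a stated time of 48 h (a lower number here means a stronger inhibitor, a higher number a weaker inhibitor), compound 2 gives 34000 nM. Compound 1 `COc1ccc2c(=O)c(/C=C/C(=O)Nc3cccc(C)c3)coc2c1` reaches only a limit in this assay, > 100000 nM. Among the measured compounds shown here, the single measured step, an at least 2.9-fold lower number from compound 1 to compound 2 (0.46 log units; beyond the scatter), is the only evidence bearing on the new change. Compound 3 `COc1ccc2c(=O)c(/C=C/C(=O)Nc3ccccc3OC)coc2c1` differs from compound 2 by 2-methoxyphenyl in place of 2-fluorobenzyl on an amide-type nitrogen, so the ring again sits directly on the amide nitrogen, as in compound 1. A step back toward a weaker inhibitor is therefore expected, a 2.4-fold higher number from compound 2 to compound 3 (0.37 log units; beyond the scatter), given that compound 1 sits at the limit of > 100000 nM in this assay, at which 1 of the 2 values shown sits. Compound 3 is estimated at 80000 nM, ranging from 30000 nM to 200000 nM.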

Compound 3, half-maximal inhibitory concentration: 17600 nM
Estimate against measurement, compound 3: 4.5-fold (0.66 log units) above; the whole stated range lies above it.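

In this assay, 2-methoxyphenyl and 2-fluorobenzyl on an amide-type nitrogen cannot be told apart, with a 1.9-fold lower number from compound 2 to compound 3 (0.29 log units; within the scatter). A phenyl ring on this nitrogen does not by itself settle the outcome: 2-methoxyphenyl and 3-methylphenyl differ clearly, with an at least 5.6-fold lower number from compound 1 to compound 3 (0.75 log units; beyond the scatter). Compound 1 reaches only a limit: the limit of > 100000 nM in this assay, at which 1 of the 3 values shown sits.

Going by these compounds, whether the difference follows the methoxy group itself or its place on the ring remains open. Also open, on these data alone, is how an amine or a carboxylic acid on the ring, or a longer chain such as 2-phenylethyl on the same nitrogen, would compare.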